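Trading benzoyl for benzylcarbamoyl: what comes next?

A few compounds are considered here, and "the series" means these few. Any claim that something is new, unique, unknown or untested is made for them only; others in the source may bear on it.

In a functional assay on MDA-MB-231 cells (Homo sapiens) for cytotoxicity, read by MTT assay, with a stated time of 96 h (on this read-out lower numbers stand for stronger inhibition and higher numbers for weaker inhibition), compound 1 `CC[C@H](N)C(=O)N[C@@H]1C(=O)N2[C@@H](CC[C@@H]1CNC(=O)NCc1ccccc1)CC[C@H]2C(=O)NC(c1ccccc1)c1ccccc1` gives 3400 nM and compound 2 `CC[C@H](N)C(=O)N[C@@H]1C(=O)N2[C@@H](CC[C@@H]1CCNC(=O)c1ccccc1)CC[C@H]2C(=O)NC(c1ccccc1)c1ccccc1` gives 930 nM, so compound 2 holds the lower, stronger number of the two. Compound 3 `CC[C@H](N)C(=O)N[C@@H]1C(=O)N2[C@@H](CC[C@@H]1CCNC(=O)NCc1ccccc1)CC[C@H]2C(=O)NC(c1ccccc1)c1ccccc1` differs from compound 2 by one change: benzylamino in place of phenyl on a carbonyl carbon. Put simply, benzylamino takes the place of phenyl on a carbonyl carbon, turning benzoyl into benzylcarbamoyl. Among the compounds with values here, only one measured step bears on this, a 3.7-fold lower number from compound 1 to compound 2 (0.56 log units; beyond the scatter), where benzamidomethyl replaced (benzylcarbamoyl)amino, roughly the reverse of the new change, but compound 3 carries ((benzylcarbamoyl)amino)methyl instead, so only part of that modest step is expected to return. A small move toward a higher number in this assay is therefore expected, a 1.8-fold higher number from compound 2 to compound 3 (0.26 log units; within the scatter). For compound 3 the estimate is 1700 nM, with an expected range of 600 nM to 4500 nM.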

Compound 3, half-maximal inhibitory concentration: 10800 nM
Estimate against measurement, compound 3: 6.4-fold (0.80 log units) below, and the stated range ends below it.
By their numbers in this assay, from the lowest: compound 2; then compound 1; then compound 3.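

In this assay, swapping benzoyl for benzylcarbamoyl on this side chain gives a 12-fold higher number from compound 2 to compound 3 (1.06 log units; beyond the scatter), a large step that shows the outcome depends strongly on what sits on this carbonyl carbon. Chain length also matters: with the benzylcarbamoyl end kept, ((benzylcarbamoyl)amino)methyl in place of (benzylcarbamoyl)amino gives a 3.2-fold higher number from compound 1 to compound 3 (0.50 log units; beyond the scatter), a modest step in the same direction. The lower number of compound 2 therefore goes with its benzoyl end, since the longer link alone moved the number up.

Nothing among the available data explains why either step occurs. Also open, from the compounds shown here alone, is how a longer chain ending in benzoyl, or a simple amine on that carbonyl carbon in place of benzylamino, would read in this assay on the same shared core.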